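The source may report more compounds than this note shows. Statements on the series, on what has been measured and on what is new or still open speak of the compounds shown alone.

In a functional assay on DU-145 cells (Homo sapiens) for cytotoxicity, read by MTT assay (on this read-out higher numbers stand for weaker inhibition and lower numbers for stronger inhibition), compound 1 `CC(C)=CC[C@@H](OC(=O)CCO)C1=CC(=O)c2c(O)ccc(O)c2C1=O` gives 55300 nM and compound 2 `CCCCC(O)CC(=O)O[C@H](CC=C(C)C)C1=CC(=O)c2c(O)ccc(O)c2C1=O` gives 45300 nM as its value, so the two lie within the scatter of each other. Compound 3 `CCC(O)CO[C@H](CC=C(C)C)C1=CC(=O)c2c(O)ccc(O)c2C1=O` awaits measurement. It differs from compound 2 by 2-hydroxybutyl in place of (2-hydroxyhexyl)carbonyl on an oxygen on a saturated carbon in one place, with 2-hydroxybutyl in place of (2-hydroxyhexyl)carbonyl on an oxygen on a saturated carbon. Within the data shown here, the only measured step is small (a 1.2-fold lower number from compound 1 to compound 2 (0.09 log units; within the scatter)) and put butyl in place of hydrogen, so it guides only loosely. A change no larger than the scatter is therefore expected, in no firm direction (a 1.3-fold lower number from compound 2 to compound 3 (0.11 log units; within the scatter)). Compound 3 is estimated at 35000 nM (range 12000 nM to 80000 nM).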

Compound 3, half-maximal inhibitory concentration: 16400 nM
For compound 3 the middle estimate is 2.1-fold (0.33 log units) above the measured one; measured number inside the range.
By their numbers in this assay, from the lowest: compound 3; then compounds 2 and 1 (each within the scatter of the next).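

On this oxygen, the swap moves the number beyond the scatter, which the earlier addition of butyl to the chain did not. In this assay, 2-hydroxybutyl gives a lower number in place of (2-hydroxyhexyl)carbonyl (a 2.8-fold lower number from compound 2 to compound 3 (0.44 log units; beyond the scatter)) and in place of (2-hydroxyethyl)carbonyl (a 3.4-fold lower number from compound 1 to compound 3 (0.53 log units; beyond the scatter)). Nothing available explains this shift.

From the compounds shown here alone, each swap removes the carbonyl and changes the chain at once, so the share of each stays unknown. Going by these compounds, how an amine or a carboxylic acid on this chain would compare also remains open.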